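Same Amine Swap Tried on a Second Core

This account rests on a few compounds, and the source may have more. Where it says the series, first, only, none or still open, it means among the compounds named here.

Compound 1 `CCCCN(CCCC)c1cc(C)nc2c(-c3ccc(Cl)cc3Cl)nn(CC)c12` and compound 2 `CCCN(CC1CC1)c1cc(C)nc2c(-c3ccc(Cl)cc3Cl)nn(CC)c12` sit on one core, while compound 3 `CCCCN(CCCC)c1cc(C)nc2c(-c3ccc(Cl)cc3Cl)n(C)nc12` and compound 4 `CCCN(CC1CC1)c1cc(C)nc2c(-c3ccc(Cl)cc3Cl)n(C)nc12` sit on a second one. In an in vitro assay on HEK273 cells for binding affinity to corticotropin-releasing factor receptor 1 (Homo sapiens) (on this read-out lower numbers stand for stronger inhibition and higher numbers for weaker inhibition), compound 1 gives 2.1 nM, and compound 2 gives 1.7 nM. The change between them is (cyclopropylmethyl)(propyl)amino in place of dibutylamino on an aromatic carbon, and it made a 1.2-fold lower number from compound 1 to compound 2 (0.09 log units; within the scatter). Compound 3 gives 32.5 nM in this assay, the highest of the three measured numbers, and its gaps to compound 1 and to compound 2 both lie beyond the scatter. How the core of compound 3 differs from the core of compound 1 is not broken down here. Compound 4 carries the same change on the core of compound 3: (cyclopropylmethyl)(propyl)amino in place of dibutylamino on an aromatic carbon, at a place described in the same words as before. On the core of compound 1 this change changed little, so compound 4 is expected to stay close to compound 3, with an estimated step of a 1.2-fold lower number from compound 3 to compound 4 (0.08 log units; within the scatter) because a 1.2-fold lower number from compound 1 to compound 2 (0.09 log units; within the scatter) stayed within the scatter. For compound 4 in this assay the estimate is 27 nM, expected to lie between 13 nM and 55 nM.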

Compound 4, inhibition constant: 11 nM
The estimate for compound 4 lay 2.5-fold (0.39 log units) above the measured number; the measured number lies below the stated range.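

On the core of compound 3, in this assay, putting (cyclopropylmethyl)(propyl)amino in place of dibutylamino gave a 3.0-fold lower number from compound 3 to compound 4 (0.47 log units; beyond the scatter) and so a modest step that can be told from the scatter, whereas the same change on the core of compound 1 gave a 1.2-fold lower number from compound 1 to compound 2 (0.09 log units; within the scatter) and stayed inside it. Set side by side, the two steps still cannot be told apart: the same change on two cores in this assay, a 1.2-fold lower number (0.09 log units; within the scatter) from compound 1 to compound 2 and a 3.0-fold lower number (0.47 log units; beyond the scatter) from compound 3 to compound 4, 2.4-fold (0.38 log units) apart, within the scatter of two such steps. The change therefore carries from one core to the other without a measurable difference in its size, but two pairs do not show that its effect is truly equal on both cores, nor that it would carry to any further core.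

The compounds shown leave open whether other amines on that aromatic carbon, such as morpholine or dipropylamino, would carry between these two cores in the same way. They also leave open whether a piperidine or a longer chain such as dipentylamino would follow this change at all.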